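The source may hold more compounds than are shown below. What is called first, only, known or untested is meant among the compounds shown, and "the series" means these compounds.

Measured so far in a functional assay on KB cells (Homo sapiens) for cytotoxicity, read by sulforhodamine B assay; a lower number here means that less compound is needed, a higher number that more compound is needed for the effect:
- compound 1 `O=C1CC(c2ccccc2)Nc2ccccc21`: 0.07 ug/mL
- compound 2 `COc1cccc(C2CC(=O)c3ccccc3N2)c1`: 0.11 ug/mL

Among the measured compounds shown here, with only two measurements, compound 2 stands level with compound 1, and the one measured step is a 1.6-fold higher number from compound 1 to compound 2 (0.20 log units; within the scatter).

Compound 3 `COc1cccc([C@@H]2CC(=O)c3ccccc3N2)c1` is the next to be read. Its relation to compound 2 is the two compounds have the same atoms and bonds; at least one stereo element is drawn with a configuration in one of them and without one in the other: 1 of 1 stereo elements differ; a stereocentre at a saturated ring carbon is drawn without a configuration in compound 2 and S in compound 3: a stereocentre at a saturated ring carbon is drawn without a configuration in compound 2 and S in compound 3.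

For the measured compounds named here, the single measured step concerns methoxy in place of hydrogen on an aromatic carbon, not a stereocentre, so it gives no direct measure of this change. Going by the values given here, no measured pair differs in drawn configuration. The data also do not say what compound 2 contains at that centre. With no measured basis for a direction, no step beyond the scatter is expected, and the expectation stays anchored on compound 2 at 0.11 ug/mL. The expected change is a 1.1-fold lower number from compound 2 to compound 3 (0.04 log units; within the scatter). The range is kept wide, and it is wider on the side of higher numbers.

For compound 3 the estimated value is 0.1 ug/mL, with an expected range from 0.03 ug/mL to 0.5 ug/mL.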

Compound 3, concentration for half-maximal effect: 0.12 ug/mL
The estimate for compound 3 lay 1.2-fold (0.08 log units) below the measured number, and the stated range covers the measured number.
By their numbers in this assay, from the lowest: compounds 1, 2 and 3 (each within the scatter of the next).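

Among the compounds shown here, until now the only measured step lay on an aromatic carbon; the stereocentre at the saturated ring carbon now has a reading of its own. In this assay, the change from an undefined drawing to S at this centre gives a 1.1-fold higher number from compound 2 to compound 3 (0.04 log units; within the scatter), so defining the centre as S in the methoxy compound goes with no step beyond the scatter. This step cannot be taken as a comparison of two defined configurations, because the difference between the two compounds amounts only to how the centre is drawn: the fact that one of compounds 2 and 3 is drawn with a defined configuration and the other without, at the place where they differ

Open, as far as these compounds go, is how the R configuration at this centre would read against S in this assay, given that the make-up of compound 2 at the centre is not stated, and whether the S drawing would read the same on the core of compound 1, which carries no methoxy. Also open, from the compounds shown here alone, is whether an amine, a carboxylic acid or a longer chain such as ethoxy in place of the methoxy would move the number beyond the scatter, with the centre held as S.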